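Lengthening the Amide Alkene on Compound 2

The source may report more compounds than this note shows. Statements on the series, on what has been measured and on what is new or still open speak of the compounds shown alone.

Two compounds were measured in a functional assay on A549 cells (Homo sapiens) for antiproliferative activity, read by MTT assay, with a stated time of 72 h; on this read-out higher numbers stand for weaker inhibition and lower numbers for stronger inhibition:

Compound 1 `CC/C=C\C(=O)Nc1cc(Nc2ncc(C#N)c(-c3cn(C)c4ccccc34)n2)c(OC)cc1N(C)CCN(C)C` gives 162 nM
Compound 2 `C=CC(=O)Nc1cc(Nc2ncc(C#N)c(-c3cn(C)c4ccc(F)cc34)n2)c(OC)cc1N(C)CCN(C)C` gives 9700 nM

Of the two numbers, compound 2 stands highest, and the nearest number is that of compound 1, a gap beyond the scatter. Compound 3 `CC/C=C\C(=O)Nc1cc(Nc2ncc(C#N)c(-c3cn(C)c4ccc(F)cc34)n2)c(OC)cc1N(C)CCN(C)C` has not been measured. It differs from compound 2 in one place: but-1-en-1-yl in place of vinyl on a carbonyl carbon. Among the compounds with values here, no pair of measured compounds differs in this one place alone, so the size of this step is not known from measurement. Compound 3 carries the same but-1-en-1-yl as compound 1, whose value is 162 nM, and compound 1 and compound 3 differ elsewhere as well, so that value is only a loose guide. The step from compound 2 to compound 3 is expected to lower the number, a 6.5-fold lower number from compound 2 to compound 3 (0.81 log units; beyond the scatter). Compound 3 is therefore estimated at 1500 nM, within a range from 200 nM to 10000 nM.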

Compound 3, half-maximal inhibitory concentration: 4730 nM
The estimate for compound 3 lay 3.2-fold (0.50 log units) below the measured number; low and high end bracket the measured number.
By their numbers in this assay, from the lowest: compound 1; then compound 3; then compound 2.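

In this assay, this position now has a measured step of its own: with the fluoro group held in place, but-1-en-1-yl on the carbonyl carbon in place of vinyl gives a 2.1-fold lower number from compound 2 to compound 3 (0.31 log units; beyond the scatter) and is a modest change. With the but-1-en-1-yl held in place, fluoro in place of hydrogen on an aromatic carbon gives a 29-fold higher number from compound 1 to compound 3 (1.47 log units; beyond the scatter) and is a large change, so of the two steps read here, the one at the aromatic carbon is the bigger. No measurement shown here accounts for the size of either step.

The compounds shown leave open whether a longer chain or a dimethylamino group on the alkene would lower the number further. They also leave open whether chloro or methoxy in place of fluoro on that aromatic carbon would bring a step of similar size.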